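A few compounds are considered here, and "the series" means these few. Any claim that something is new, unique, unknown or untested is made for them only; others in the source may bear on it.

Compound 1, `COc1cc2ccc(=O)oc2cc1OCCOc1no[n+]([O-])c1S(=O)(=O)c1ccccc1`, gives 89.2% in a functional assay on MCF7 cells (Homo sapiens) for inhibition, read by MTT assay, with a stated time of 48 h, tested at 10 uM; a higher number here means more inhibition at the concentration tested (going by the name of the read-out), a lower number less inhibition.
Compound 2, `COc1cc2ccc(=O)oc2cc1OCCCOc1no[n+]([O-])c1S(=O)(=O)c1ccccc1`, gives 88.6% in this assay.
Compound 3, `COc1cc2ccc(=O)oc2cc1OCCCCCOc1c[n+]([O-])on1`, gives 87.1% in this assay.

Compound 2 sits second highest of these three numbers, yet the number of compound 1 differs from it by an amount within the usual scatter, and so does the number of compound 3. The three measured compounds therefore cannot be told apart in this assay: each blocks the growth of the cells strongly at the concentration tested, whatever the length of the chain that joins the two parts of the molecule.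

Compound 4, `COc1cc2cc(NC(C)=O)c(=O)oc2cc1OCCCOc1no[n+]([O-])c1S(=O)(=O)c1ccccc1`, has not yet been measured in this assay. Compared with compound 2 it carries one change: acetamido in place of hydrogen on an aromatic carbon. Among the compounds with values here, no pair among the measured compounds differs in this way, so nothing measured shows what such an addition does here. Since every measured compound gives a number in the same high band, the expectation for compound 4 is no step beyond the scatter in this assay, in either direction. The step from compound 2 to compound 4 is estimated as a number 3.6 percentage points lower from compound 2 to compound 4 (within the scatter). Compound 4 is thus expected to give about 85%, within a range from 70% to 93%.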

Compound 4, a percentage reported as inhibition, at one concentration (the size of the read-out at that concentration, not a potency): 88.5%
Estimate against measurement, compound 4: 3.5 percentage points below; measured number inside the range.
By their numbers in this assay, from the lowest: compounds 3, 4, 2 and 1 (each within the scatter of the next).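

The earlier compounds shown here differed in the chain and in the group on the far ring, so they said nothing about substitution on the shared core. Here, putting acetamido in place of hydrogen on an aromatic carbon, two atoms from the ring oxygen, gives in this assay a step of a number 0.1 percentage points lower from compound 2 to compound 4 (within the scatter) and so shows that this position can carry a group of 4 heavy atoms, with a hydrogen-bond donor and a hydrogen-bond acceptor, and the strong inhibition of the cells remains. Nothing among the data explains why the reading holds.

As far as these compounds go, each reading comes from a single concentration and all of them lie in the same high band, so a real difference in potency between compound 2 and compound 4 could stay hidden, and it remains open whether a lower concentration would separate them. From the compounds shown here alone, it also remains open whether a different group at this position, such as an amine, a carboxylic acid or a longer amide chain, would leave the inhibition just as high.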